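Aromatic amine cap variation in the cyclohexyl dione series

The source may report more compounds than this note shows. Statements on the series, on what has been measured and on what is new or still open speak of the compounds shown alone.

Compound 2 `CC[C@H]1CC[C@H](n2c(=O)[nH]c3ncc(NC(C)=O)cc3c2=O)CC1` gives 215000 nM in an ADME assay on L6 cells (Rattus norvegicus) for cytotoxicity, read by resazurin assay, with a stated time of 70 h (on this read-out higher numbers stand for an effect only at larger amounts of compound and lower numbers for an effect already at smaller amounts), the highest of the three numbers measured. Compound 3 `CC(=O)Nc1cnc2[nH]c(=O)n(CCC3CCCCC3)c(=O)c2c1` gives 130000 nM, and a 1.7-fold lower number from compound 2 to compound 3 (0.22 log units; within the scatter). Compound 1 `CC(=O)Nc1cnc2[nH]c(=O)n([C@H]3CC[C@H](C(C)C)CC3)c(=O)c2c1` gives 32000 nM, and a 6.7-fold higher number from compound 1 to compound 2 (0.83 log units; beyond the scatter). Compound 4 `CC[C@H]1CC[C@H](n2c(=O)[nH]c3ncc(N)cc3c2=O)CC1` differs from compound 2 as follows: hydrogen in place of acetyl on a nitrogen on an aromatic ring. Both measured steps change the group on the aromatic nitrogen and leave the acetamido untouched, so neither bears directly on this change; the data hold nothing on acetamido to amino. Going by the values given here, with no steps to lean on, the expectation for compound 4 in this assay is a number near that of compound 2, with a wide range and no step beyond the scatter: a 1.1-fold lower number from compound 2 to compound 4 (0.03 log units; within the scatter). Compound 4 is estimated at 200000 nM, within 60000 nM to 600000 nM.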

Compound 4, half-maximal effective concentration: 51000 nM
Beside the measured number, compound 4's estimate is 3.9-fold (0.59 log units) above it; the whole stated range lies above it.
By their numbers in this assay, from the lowest: compounds 1 and 4 (each within the scatter of the next); then compounds 3 and 2 (each within the scatter of the next).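

In this assay the change from acetamido to amino gives a 4.2-fold lower number from compound 2 to compound 4 (0.62 log units; beyond the scatter), a modest step beyond the scatter. The earlier steps shown here all changed the group on the aromatic nitrogen, so this shows that the read-out also responds to the group on the nitrogen on the aromatic ring. Nothing available here accounts for this shift.

Open, as far as these compounds go, is whether a propionyl amide, a methanesulfonamide or a methylamine at this place would read nearer compound 2 or compound 4. Also open, from the compounds shown here alone, is whether acetamido to amino keeps its size with a group other than 4-ethylcyclohexyl on the aromatic nitrogen.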